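From phenyl to a larger group on the amine

The source may report more compounds than this note shows. Statements on the series, on what has been measured and on what is new or still open speak of the compounds shown alone.

Compound 1 `CC(O)c1ccc(C(=O)N[C@@H](C)Cn2ccc(-c3ccc(C#N)c(Cl)c3)n2)cc1`: 9050 nM
Compound 2 `C[C@@H](Cn1ccc(-c2ccc(C#N)c(Cl)c2)n1)Nc1ccccc1`: > 30000 nM (a limit)
Compound 3 `C[C@@H](Cn1ccc(-c2ccc(C#N)c(Cl)c2)n1)Nc1ccnc2ccccc12`: 4290 nM

All three compounds were tested in a functional assay on CWR22R cells (Homo sapiens) for antiproliferative activity, read by CCK-8 assay, with a stated time of 6 days; on this read-out lower numbers stand for stronger inhibition and higher numbers for weaker inhibition. Compound 2 has only a limit in this assay, > 30000 nM, and not an exact number. Its true position on the scale is therefore open.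

The next compound to consider is compound 4 `C[C@@H](Cn1ccc(-c2ccc(C#N)c(Cl)c2)n1)Nc1ncnc2nc[nH]c12`, which keeps the rest of compound 2 and changes one group: a group of 9 heavy atoms (5 carbon, 4 nitrogen; one five-membered aromatic ring with 2 hetero atoms, one six-membered aromatic ring with 2 hetero atoms) in place of a group of 6 heavy atoms (6 carbon; one six-membered aromatic ring of carbon only), on an amine nitrogen. Phenyl leaves, and a larger group with more nitrogen enters on the same amine nitrogen.

Among the measured compounds shown here, no measured pair in this set isolates such a swap, so any forecast is rough. It leans on compound 3, which gives 4290 nM, showing that a measurable number is reachable with a different group on that amine nitrogen. A shift toward stronger inhibition is expected, with an estimated size of an at least 3.3-fold lower number from compound 2 to compound 4 (0.52 log units; beyond the scatter). For compound 4 the expected value is 9000 nM, within an estimated range of 2500 nM to 30000 nM.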

Compound 4, half-maximal inhibitory concentration: 4240 nM
For compound 4 the middle estimate is 2.1-fold (0.33 log units) above the measured one, and the stated range covers the measured number.
By their numbers in this assay, from the lowest: compounds 4 and 3 (each within the scatter of the next); then compound 1. At a limit, above all of these: compound 2.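

Among the compounds shown here, replacing phenyl on this amine nitrogen with a group of one five-membered and one six-membered aromatic ring gives an at least 7.0-fold lower number from compound 2 to compound 4 (0.84 log units; beyond the scatter), the first step at this position that can be read. Compound 2 has a limit and not an exact number, so the step fixes only a minimum size and its true size stays open: the limit of > 30000 nM in this assay, at which 1 of the 4 values shown sits.

Compound 3 gives 4290 nM and compound 4 gives 4240 nM, values within the scatter of each other, so two different groups on this nitrogen land at the same level.

The compounds shown do not tell which ring of the entering group accounts for the step; a lone pyrimidine or a lone imidazole on the same amine nitrogen would separate the two. They also leave open how far this position can go.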